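The compounds below may be only part of what the source reports. "The series", "measured", "known", "first", "only" and "open" are said of these compounds alone.

Series notes, a functional assay for agonist activity at follicle-stimulating hormone receptor (Homo sapiens), read by a luciferase reporter; a lower number here means that less compound is needed, a higher number that more compound is needed for the effect.

Compound 1 `CCCCCCN1C(=O)[C@H](Cc2ccc(-c3cc(OC)c(OC)c(OC)c3)cc2)N(C)C(=O)[C@@H]1C` gives 100 nM in this assay. Compound 2 `CCCCCCCCN1C(=O)[C@H](Cc2ccc(-c3cc(OC)c(OC)c(OC)c3)cc2)N(C)C(=O)[C@@H]1C` gives 13 nM. The change between them, (ethyl in place of hydrogen on a saturated chain carbon, six bonds along the chain from an amide-type nitrogen in a ring), produced a 7.7-fold lower number from compound 1 to compound 2 (0.89 log units; beyond the scatter).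

Compound 3 `CCCCCCN1C(=O)[C@H](Cc2ccc(-c3cccc(CN(CCCC)C(=O)NC)c3)cc2)N(C)C(=O)[C@@H]1C` gives 7.2 nM; its number stands within the scatter of compound 2 and beyond the scatter of compound 1. The difference between the core of compound 3 and the core of compound 1 is not broken down here.

Compound 4 `CCCCCCCCN1C(=O)[C@H](Cc2ccc(-c3cccc(CN(CCCC)C(=O)NC)c3)cc2)N(C)C(=O)[C@@H]1C` has not yet been measured in this assay. It differs from compound 3 by ethyl in place of hydrogen on a saturated chain carbon, six bonds along the chain from an amide-type nitrogen in a ring, the same change, at the same place, as from compound 1 to compound 2. On the strength of compound 3 giving 7.2 nM and the earlier step of a 7.7-fold lower number from compound 1 to compound 2 (0.89 log units; beyond the scatter), the step from compound 3 to compound 4 is expected to be around a 4.8-fold lower number from compound 3 to compound 4 (0.68 log units; beyond the scatter). Compound 4 is therefore estimated at 1.5 nM, with a likely range from 0.5 nM to 5 nM.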

Compound 4, half-maximal effective concentration: 1.2 nM
Estimate against measurement, compound 4: 1.3-fold (0.10 log units) above; measured number inside the range.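

In this assay, ethyl in place of hydrogen on a saturated chain carbon, six bonds along the chain from an amide-type nitrogen in a ring, gives a 6.0-fold lower number from compound 3 to compound 4 (0.78 log units; beyond the scatter). The change carries from one core to the other, and the size of the step does not differ between them: the same change on two cores in this assay, a 7.7-fold lower number (0.89 log units; beyond the scatter) from compound 1 to compound 2 and a 6.0-fold lower number (0.78 log units; beyond the scatter) from compound 3 to compound 4, 1.3-fold (0.11 log units) apart, within the scatter of two such steps

This rests on two pairs only, so it shows that the step held on these two cores, not that it would hold on any other core, and it gives no reason for the step.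

Still open, going by these compounds, is whether a longer chain would lower the number further in this assay. Also open, on these data alone, is how a chain ending in an amine or a carboxylic acid would read on either core.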